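Swapping a Propyl Chain for a Chlorophenyl Ring

The compounds below may be only part of what the source reports. "The series", "measured", "known", "first", "only" and "open" are said of these compounds alone.

Compound 1 has the structure `CCCC(=O)Nc1ncc(-c2ccc(OC)cc2)n1C`. In a toxicity assay on THP-1 cells (Homo sapiens) for inhibition (a higher number here means that more compound is tolerated, a lower number that less compound is tolerated), compound 1 gives > 100000 nM, which is a limit of the assay rather than a measured number. A second compound, compound 2, with the structure `CCn1c(-c2ccc(OC)cc2)cnc1NC(=O)c1ccc(F)cc1`, was tested alongside it. In this assay compound 2 gives > 100000 nM, again a limit and not a number. Both results therefore sit at the same ceiling, as the note the limit of > 100000 nM in this assay, at which 2 of the 2 values shown sit, records, so nothing measured separates compound 1 from compound 2.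

Compound 3, with the structure `COc1ccc(-c2cnc(NC(=O)c3cccc(Cl)c3)n2C)cc1`, has not yet been tested. It differs from compound 1 in one place, as counted here: 3-chlorophenyl in place of propyl on a carbonyl carbon.

Among the compounds with values here, no step between two measured compounds is available to guide the size of this change. Within the data shown here, the only evidence, (the limit of > 100000 nM in this assay, at which 2 of the 2 values shown sit), shows that both measured compounds tolerate the top concentration. The expected step from compound 1 to compound 3 is a number no higher from compound 1 to compound 3 (the limit leaves the size open), within the scatter. Compound 3 is therefore expected to give about 100000 nM in this assay, with a range from 30000 nM to 300000 nM.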

Compound 3, half-maximal cytotoxic concentration: > 28000 nM
Compound 3 gave a limit, no number (the forecaster's own chance of this, stated with the estimate: 65%); the middle value lies beyond the limit too.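

In this assay compound 3 gives > 28000 nM, which is a limit of the assay and not a number. Compound 1 also stands at a limit, so the step between compound 1 and compound 3 cannot be read. The compounds shown leave open whether 3-chlorophenyl in place of propyl changes how much compound the cells tolerate.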